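Caffeic acid piperazine amides: a dichlorophenyl variant

The source may report more compounds than this note shows. Statements on the series, on what has been measured and on what is new or still open speak of the compounds shown alone.

Measured compounds:
Compound 1, `O=C(/C=C/c1ccc(O)c(O)c1)N1CCN(c2ccc(F)cc2)CC1`, 1.44 ug/mL
Compound 2, `Cc1ccc(N2CCN(C(=O)/C=C/c3ccc(O)c(O)c3)CC2)c(C)c1`, 0.78 ug/mL

Of the compounds shown here, two have been tested in a functional assay on MCF7 cells (Homo sapiens) for antiproliferative activity, read by MTT assay, with a stated time of 48 h; a higher number here means a weaker inhibitor, a lower number a stronger inhibitor. Compound 1 gives 1.44 ug/mL, and compound 2 gives 0.78 ug/mL. Among these two numbers compound 1 has the higher one, but the only step so far, a 1.8-fold lower number from compound 1 to compound 2 (0.27 log units; within the scatter), is within the scatter, so the two compounds cannot be separated with confidence.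

Compound 3, `O=C(/C=C/c1ccc(O)c(O)c1)N1CCN(c2ccc(Cl)c(Cl)c2)CC1`, has not yet been measured. It differs from compound 1 in one place: 3,4-dichlorophenyl in place of 4-fluorophenyl on an amine nitrogen in a ring. Within the data shown here, the single measured step bears on this change only loosely, since it swaps the 4-fluorophenyl for a different aryl group, and that step, a 1.8-fold lower number from compound 1 to compound 2 (0.27 log units; within the scatter), stayed within the scatter. Among the measured compounds shown here, there is no measured example of a 3,4-dichlorophenyl on this core, so nothing in hand points to a step beyond the scatter in either direction.

On this basis compound 3 is expected to give about 1 ug/mL in this assay, within a range from 0.4 ug/mL to 2.5 ug/mL. The expected step, a 1.4-fold lower number from compound 1 to compound 3 (0.16 log units; within the scatter), is estimated to remain within the scatter.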

Compound 3, half-maximal inhibitory concentration: 1.28 ug/mL
Compound 3: the middle estimate sits 1.3-fold (0.11 log units) below what was measured, within the range that was stated.
By their numbers in this assay, from the lowest: compounds 2, 3 and 1 (each within the scatter of the next).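

In this assay, placing 3,4-dichlorophenyl on the amine nitrogen in the ring in place of 4-fluorophenyl gives a 1.1-fold lower number from compound 1 to compound 3 (0.05 log units; within the scatter) and placing it there in place of 2,4-dimethylphenyl gives a 1.6-fold higher number from compound 2 to compound 3 (0.22 log units; within the scatter) so the new group cannot be separated from either earlier aryl group. Among these compounds, the earlier compounds offered only one comparison at this position, whereas three differently substituted phenyl groups now stand on the same nitrogen of the shared core, with every step between them within the scatter. Among these compounds, neither the dichloro pattern nor the change from the fluoro or dimethyl pattern yields a step that can be told from the scatter, and nothing at hand explains this result.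

All three compounds carry a six-membered aromatic ring of carbon only on this nitrogen, so they leave open whether a pyridine ring, a benzyl group or a saturated cyclohexyl group there would produce a step beyond the scatter. They also leave open how the number would respond if methoxy groups took the place of the hydroxyl groups elsewhere on the shared core.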